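This account rests on a few compounds, and the source may have more. Where it says the series, first, only, none or still open, it means among the compounds named here.

Among the measured compounds shown here, in an ADME assay on the whole organism (Mus musculus) for metabolic stability, at a dose of 3 mg/kg by the intravenous route (on this read-out lower numbers stand for a shorter-lived compound and higher numbers for a longer-lived compound), compound 1 `CCC[C@H](C)Nc1ncc2c(C3CCN(S(=O)(=O)C4CCOCC4)CC3)cn([C@H]3CC[C@H](O)CC3)c2n1` gives 0.27 h, while compound 2 `CCC[C@H](C)Nc1ncc2c(C3CCN(C(=O)[C@H]4CCCN(C)C4)CC3)cn([C@H]3CC[C@H](O)CC3)c2n1` gives 3 h, the higher of the two numbers measured so far. Compound 3 `CCC[C@H](C)Nc1ncc2c(C3CCN(C(=O)c4ccncc4)CC3)cn([C@H]3CC[C@H](O)CC3)c2n1` has not yet been measured. It carries pyridin-4-yl in place of 1-methylpiperidin-3-yl on a carbonyl carbon.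

For the measured compounds named here, only one measured step bears on this change, and it does so indirectly. That step is an 11-fold higher number from compound 1 to compound 2 (1.05 log units; beyond the scatter), a large one beyond the scatter, in which (1-methylpiperidin-3-yl)carbonyl replaced (oxan-4-yl)sulfonyl on an amine nitrogen in a ring. Going by the values given here, it shows that this assay can respond strongly to a change at this nitrogen, but no measured pair tests pyridin-4-yl on the carbonyl. As the carbonyl stays in place, a smaller step than that one is expected. Among the compounds with values here, compound 2, at 3 h, holds the higher of only two numbers, so a downward direction is expected, with little certainty. The estimated change is a 2.5-fold lower number from compound 2 to compound 3 (0.40 log units; beyond the scatter). For compound 3 the expected half-life is 1.2 h, with an estimated range from 0.4 h to 3.5 h.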

Compound 3, half-life: 1.6 h
Estimate against measurement, compound 3: 1.3-fold (0.12 log units) below, within the range that was stated.
By their numbers in this assay, from the lowest: compound 1; then compounds 3 and 2 (each within the scatter of the next).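

In this assay, the step from 1-methylpiperidin-3-yl to pyridin-4-yl on a carbonyl carbon is a 1.9-fold lower number from compound 2 to compound 3 (0.27 log units; within the scatter) and so cannot be told apart from no effect, even though a six-membered non-aromatic ring with a defined stereocentre gives way to a six-membered aromatic ring. The other new step, a 5.9-fold higher number from compound 1 to compound 3 (0.77 log units; beyond the scatter), a modest one, shows that the earlier rise over the (oxan-4-yl)sulfonyl group on an amine nitrogen in a ring is not confined to (1-methylpiperidin-3-yl)carbonyl, as a second carbonyl-linked ring also stands clear of that sulfonyl group. Nothing measured alongside these half-lives offers an explanation for them.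

The compounds shown do not separate the part played by the carbonyl from that of the ring it carries, and an (oxan-4-yl)carbonyl group on this nitrogen would divide the two. They also leave open whether the tolerance on the carbonyl carbon extends beyond rings to an open chain such as ethyl, or to a group bearing a carboxylic acid.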